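Trading a Fluorophenyl Ketone for a Pyridyl Ring

A few compounds are considered here, and "the series" means these few. Any claim that something is new, unique, unknown or untested is made for them only; others in the source may bear on it.

Of the compounds shown here, three built on one shared core have been measured in a functional assay (aorta) with Rattus norvegicus as the target; a lower number here means a less potent compound, a higher number a more potent compound, by a factor of ten per unit of this negative logarithm. Compound 1 `COc1ccc(C(=O)c2ccc3c(c2)C(n2ccccc2=O)=CC(C)(C)O3)cc1` gives 6.15, and compound 2 `CC1(C)C=C(n2ccccc2=O)c2cc(C(=O)c3ccc([N+](=O)[O-])cc3)ccc2O1` gives 6.2; the step of a number 0.05 log units higher from compound 1 to compound 2 (within the scatter) is too small to trust. Compound 3 `CC1(C)C=C(n2ccccc2=O)c2cc(C(=O)c3ccccc3F)ccc2O1` gives 7.08, the highest of the three numbers, and both steps toward it, a number 0.93 log units higher from compound 1 to compound 3 (beyond the scatter) and a number 0.88 log units higher from compound 2 to compound 3 (beyond the scatter), are modest yet beyond the scatter.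

Compound 4 `CC1(C)C=C(n2ccccc2=O)c2cc(-c3ccncc3)ccc2O1` differs from compound 3 in a single place: pyridin-4-yl in place of (2-fluorophenyl)carbonyl on an aromatic carbon. Among the compounds with values here, no measured step removes the carbonyl or brings in pyridin-4-yl, so the two steps toward compound 3 bear on this change only loosely: they show that swapping the aromatic ring on the carbonyl carbon moves the read-out by modest amounts. The change here is larger, with the carbonyl itself gone as well. A modest drop from compound 3 is therefore expected, a number 0.58 log units lower from compound 3 to compound 4 (beyond the scatter). Compound 4 is estimated at 6.5, in a range from 5.6 to 7.4.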

Compound 4, logarithm of the reciprocal of the active concentration, log(1/C): 6.68
The estimate for compound 4 lay 0.18 log units below the measured number; the measured number falls inside the stated range.
By their numbers in this assay, from the lowest: compounds 1 and 2 (each within the scatter of the next); then compound 4; then compound 3.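

In this assay the swap gives a number 0.40 log units lower from compound 3 to compound 4 (beyond the scatter), the first sign that a carbonyl is not essential at this position: a ring bonded directly to the aromatic carbon of the shared core still gives a measurable read-out. Compound 4 at 6.68 also stands above compound 1 at 6.15 and compound 2 at 6.2, so among these compounds, keeping the carbonyl does not by itself give the higher number. Nothing measured here explains the drop, and the loss of the carbonyl cannot be separated from the change of ring.

On these data alone, a plain phenyl on the same carbon, or a pyridin-4-yl ring held on a carbonyl, would help separate those two changes, and both remain open. As far as these compounds go, how an amine or a carboxylic acid at this position would read also stays open.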